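The compounds below may be only part of what the source reports. "The series", "measured", "known", "first", "only" and "open" are said of these compounds alone.

Compound 1 `CC(C)OC(=O)N1CCC(Oc2ncnc3c2CCN3c2ccc(S(C)(=O)=O)cc2)CC1` stands at the top of the three measured compounds in a functional assay on CHO-K1 cells with Glucose-dependent insulinotropic receptor (Homo sapiens) as the target, read by a luciferase reporter, with a stated time of 5 h (a higher number here means a larger maximal response, a lower number a smaller maximal response), where compound 1 reaches 154%. Its nearest neighbour is compound 3 `CC(C)c1noc(N2CCC(O)CC2)n1`, which in this assay gives 105%, a difference that lies beyond the usual scatter. Furthest away is compound 2 `CN(C)S(=O)(=O)N1CCC(Oc2ncnc3c2CCN3c2ccc(S(C)(=O)=O)cc2F)CC1`, which in this assay gives 68%, again well beyond the scatter. No pair among these three differs in only one place, so no single structural step has yet been measured.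

Compound 4 `CC(C)OC(=O)N1CCC(Oc2ncnc3c2CCN3c2ccc(S(C)(=O)=O)cn2)CC1` is the unmeasured analogue of compound 1. The change is 5-(methylsulfonyl)pyridin-2-yl in place of 4-(methylsulfonyl)phenyl on a nitrogen on an aromatic ring in a ring. Because compound 1 gives 154% and the change is confined to one ring, compound 4 is expected to stay close to it, with at most a modest drop in maximal response, a step from compound 1 that may or may not exceed the scatter: a number 19 percentage points lower from compound 1 to compound 4 (beyond the scatter). In this assay compound 4 is therefore estimated at 135%, within a range from 95% to 165%.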

Compound 4, largest response reached (reported as percent of maximum), in percent of the reference or control that the assay uses: 111%
Beside the measured number, compound 4's estimate is 24 percentage points above it; low and high end bracket the measured number.
By their numbers in this assay, from the lowest: compound 2; then compounds 3 and 4 (each within the scatter of the next); then compound 1.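

Within the data shown here, the first single-place step in this set falls on the aromatic group carried by the nitrogen of the five-membered non-aromatic ring: in this assay, 5-(methylsulfonyl)pyridin-2-yl in place of 4-(methylsulfonyl)phenyl gives a number 43 percentage points lower from compound 1 to compound 4 (beyond the scatter). Both groups have the same number of heavy atoms and keep the methylsulfonyl group, so exchanging one ring carbon for nitrogen is enough to change the maximal response well beyond the scatter. No measurement is available that accounts for this step.

On these data alone, it remains open whether a pyrimidine ring at this place would lower the maximal response further, or whether a nitrile in place of methylsulfonyl would change it as well. It is also unknown whether the same exchange gives a step of similar size when the isopropyl carbamate on the piperidine nitrogen is replaced by another group.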